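A few compounds are considered here, and "the series" means these few. Any claim that something is new, unique, unknown or untested is made for them only; others in the source may bear on it.

The compounds share one core, a carbamate on a ring nitrogen whose ester oxygen carries a small branched group. Compound 1 `Cc1nc(S(C)(=O)=O)ccc1Oc1ncnc(OC2CCN(C(=O)OC(C)(C)C(F)(F)F)CC2)c1F` has a 1-methyl-1-(trifluoromethyl)ethyl group there; in a functional assay on isolated protein for inhibition of Glucose-dependent insulinotropic receptor (Homo sapiens), read by HTRF and cAMP accumulation (a higher number here means that more compound is needed for the effect, a lower number that less compound is needed), compound 1 gives 6.53 nM. Compound 2 `Cc1nc(S(C)(=O)=O)ccc1Oc1ncnc(OC2CCN(C(=O)O[C@H](C)CF)CC2)c1F` carries a 1-(fluoromethyl)ethyl group instead, and in this assay compound 2 gives 196 nM. Compound 3 `Cc1nc(S(C)(=O)=O)ccc1Oc1ncnc(OC2CCN(C(=O)O[C@H](C)C(F)(F)F)CC2)c1F` carries a 1-(trifluoromethyl)ethyl group, and in this assay compound 3 gives 9.2 nM.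

Among these three numbers compound 3 stands second highest: its nearest neighbour is compound 1, with a 1.4-fold higher number from compound 1 to compound 3 (0.15 log units; within the scatter), while compound 2 lies far away, with a 21-fold lower number from compound 2 to compound 3 (1.33 log units; beyond the scatter). Within the data shown here, the change of group, a 30-fold higher number from compound 1 to compound 2 (1.48 log units; beyond the scatter), is the only step of a large size.

Compound 4 `Cc1nc(S(C)(=O)=O)ccc1Oc1ncnc(OC2CCN(C(=O)O[C@@H](C)C(F)(F)F)CC2)c1F` is the mirror-image partner of compound 3: the two compounds have the same atoms and bonds and differ only in configuration as drawn: 1 of 1 stereo elements differ; a stereocentre at a saturated chain carbon is drawn R in compound 3 and S in compound 4. Among the measured compounds shown here, none of the measured steps changes configuration, so no step bears directly on this one; the nearest guide is that compound 3 sits within the scatter of compound 1, which has no stereocentre at all and gives 6.53 nM. The step in this assay is therefore expected to be modest, a 2.0-fold higher number from compound 3 to compound 4 (0.29 log units; within the scatter), with a wide range. Compound 4 is estimated at 18 nM, between 5 nM and 90 nM.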

Compound 4, half-maximal effective concentration: 9.86 nM
Compound 4: middle estimate off by 1.8-fold (0.26 log units), on the high side; measured number inside the range.
By their numbers in this assay, from the lowest: compounds 1, 3 and 4 (each within the scatter of the next); then compound 2.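

Configuration at this carbon turns out to matter very little in this assay, with a 1.1-fold higher number from compound 3 to compound 4 (0.03 log units; within the scatter), and this step can be read as the effect of configuration alone because nothing else in the structure changes: the fact that compounds 3 and 4 differ only in the configuration as drawn. Compound 4 also sits close to the compound with no stereocentre at this carbon, with a 1.5-fold higher number from compound 1 to compound 4 (0.18 log units; within the scatter), so in this assay the 1-methyl-1-(trifluoromethyl)ethyl group and both mirror-image forms of the 1-(trifluoromethyl)ethyl group cannot be told apart. The large gap to the fluoromethyl-bearing compound also appears with the opposite configuration, with a 20-fold lower number from compound 2 to compound 4 (1.30 log units; beyond the scatter), so among these compounds the trifluoromethyl group goes with the low numbers whichever way the stereocentre is drawn.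

The compounds shown leave open whether the mirror-image partner of compound 2 would also match compound 2, since the insensitivity to configuration is seen only for the 1-(trifluoromethyl)ethyl group. They also leave open how a difluoromethyl group at this carbon would fall between the fluoromethyl and trifluoromethyl results, and whether a longer chain such as a pentafluoroethyl group would keep the number as low.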